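Pyridin-2-yl to pyridin-3-yl on the chlorothiophene-furan pair

This account rests on a few compounds, and the source may have more. Where it says the series, first, only, none or still open, it means among the compounds named here.

In a functional assay on DU-145 cells (Homo sapiens) for cytotoxicity, read by ELISA, with a stated time of 4 days (on this read-out higher numbers stand for weaker inhibition and lower numbers for stronger inhibition), compound 1 `Cc1cccc(-c2cc(-c3ccoc3)cc(-c3ccc(Cl)s3)n2)c1` gives 20300 nM and compound 2 `Clc1ccc(-c2cc(-c3ccoc3)cc(-c3ccccn3)n2)s1` gives 20500 nM. Within the data shown here, these two values lie within the scatter of each other, so compound 2 holds no place of its own on the numbers so far. Among the measured compounds shown here, the only measured step, with pyridin-2-yl in place of 3-methylphenyl on an aromatic carbon, is a 1.0-fold higher number from compound 1 to compound 2 (0.00 log units; within the scatter).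

Compound 3 `Clc1ccc(-c2cc(-c3ccoc3)cc(-c3cccnc3)n2)s1` carries the next change: pyridin-3-yl in place of pyridin-2-yl on an aromatic carbon. Pyridin-3-yl stands in place of pyridin-2-yl, next to the ring nitrogen of the shared core. For the measured compounds named here, no measured step covers this exact exchange, and the evidence is a single pair at the same place. That one exchange gave compound 2 at 20500 nM, within the scatter of its partner, so no step beyond the scatter is expected in this assay. The expected move is a 1.1-fold lower number from compound 2 to compound 3 (0.06 log units; within the scatter), with no direction favoured. For compound 3 the estimated value is 18000 nM, with an expected range of 7000 nM to 40000 nM.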

Compound 3, half-maximal inhibitory concentration: 18500 nM
For compound 3 the middle estimate is 1.0-fold (0.01 log units) below the measured one; the range from low to high includes it.
By their numbers in this assay, from the lowest: compounds 3, 1 and 2 (each within the scatter of the next).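

With the shared core, the 5-chlorothiophen-2-yl group and the furan-3-yl group held fixed, this series now has a change of attachment alone at the place next to the ring nitrogen: the same atoms, joined differently, give a 1.1-fold lower number from compound 2 to compound 3 (0.04 log units; within the scatter) in this assay. Set against the carbocyclic partner, pyridin-3-yl in place of 3-methylphenyl gives a 1.1-fold lower number from compound 1 to compound 3 (0.04 log units; within the scatter), so this second pyridine also stays within the scatter of the 3-methylphenyl compound, and the three groups tried at this place cannot be told apart on these numbers. No measurement available here accounts for this flat picture.

All three values sit close together, so the compounds shown do not tell whether this place can move the read-out at all, or whether a group of another kind there, such as an aminomethyl group, a carboxylic acid or a longer alkyl chain, would give a step beyond the scatter. From the compounds shown here alone, the contribution of the 5-chlorothiophen-2-yl and furan-3-yl groups also remains open, since neither varies across compound 1, compound 2 and compound 3.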